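From Methyl to Benzyloxy on the Shared Core

A few compounds are considered here, and "the series" means these few. Any claim that something is new, unique, unknown or untested is made for them only; others in the source may bear on it.

For the measured compounds named here, compound 2 `CCc1nc(N)nc(N)c1-c1ccc(NCc2cc(F)c(S(=O)(=O)C(F)(F)F)c(F)c2)cc1` gives 21 nM in an in vitro assay on CHOK cells for displacement of a labelled ligand from growth hormone secretagogue receptor type 1 (Homo sapiens) (on this read-out lower numbers stand for stronger inhibition and higher numbers for weaker inhibition), the higher of the two numbers measured so far. Its nearest neighbour is compound 1 `CCc1nc(N)nc(N)c1-c1ccc(NCc2cc(F)c(S(C)(=O)=O)c(F)c2)cc1`, which gives 2.4 nM in this assay; putting trifluoromethyl in place of methyl on the sulfonyl sulfur gave an 8.8-fold higher number from compound 1 to compound 2 (0.94 log units; beyond the scatter). Compound 3 `Nc1nc(N)c(-c2ccc(NCc3cc(F)c(S(=O)(=O)C(F)(F)F)c(F)c3)cc2)c(COCc2ccccc2)n1` has not yet been measured. It differs from compound 2 by benzyloxy in place of methyl on a saturated chain carbon bound to an aromatic carbon. Going by the values given here, no measured step bears on this change: the only step recorded concerns the sulfonyl group, at a different place on the shared core, and how a larger group on the chain affects this assay is simply unknown. The expectation for compound 3 therefore stays close to compound 2, with a wide range on either side, and compound 3 is estimated to give 25 nM (from 5 nM to 120 nM). That estimate amounts to an expected 1.2-fold higher number from compound 2 to compound 3 (0.08 log units; within the scatter).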

Compound 3, half-maximal inhibitory concentration: 1 nM
Estimate against measurement, compound 3: 25-fold (1.40 log units) above, outside the stated range (below it).
By their numbers in this assay, from the lowest: compound 3; then compound 1; then compound 2.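

Benzyloxy in place of methyl on a saturated chain carbon bound to an aromatic carbon gave a 21-fold lower number from compound 2 to compound 3 (1.32 log units; beyond the scatter) in this assay, so this place on the shared core strongly affects the read-out, which the sulfonyl step alone could not show. The much larger group, with its six-membered aromatic ring, is accepted here, and the stronger inhibition appears even with trifluoromethyl on the sulfonyl sulfur, the change that had raised the number earlier. No available evidence explains why the number falls.

The compounds shown leave open whether the gain comes from the aromatic ring, the oxygen or the added length, which a methoxymethyl or a phenylpropyl group at this place would help separate. They also leave open whether benzyloxy gives a similar gain with methyl on the sulfonyl sulfur.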